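Series notes: swapping 4-aminocyclohexyl in the furan-2-yl compound

The source may report more compounds than this note shows. Statements on the series, on what has been measured and on what is new or still open speak of the compounds shown alone.

In a functional assay on HeLa cells (Homo sapiens) for inhibition, with a stated time of 72 h (on this read-out higher numbers stand for weaker inhibition and lower numbers for stronger inhibition), compound 1 `NC1CCC(Nc2nc(NCc3ccc(Br)cc3)c3ncn(C4CCCC4)c3n2)CC1` gives 1510 nM, compound 2 `COc1ccccc1-c1ccc(CNc2nc(NC3CCC(N)CC3)nc3c2ncn3C2CCCC2)cc1` gives 333 nM and compound 3 `NC1CCC(Nc2nc(NCc3ccc(-c4ccco4)cc3)c3ncn(C4CCCC4)c3n2)CC1` gives 71 nM. Compound 3 therefore has the lowest number of the three, with both gaps beyond the scatter.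

These compounds differ only in the group on an aromatic carbon. The steps are a 4.5-fold lower number from compound 1 to compound 2 (0.66 log units; beyond the scatter), a 4.7-fold lower number from compound 2 to compound 3 (0.67 log units; beyond the scatter) and a 21-fold lower number from compound 1 to compound 3 (1.33 log units; beyond the scatter).

Compound 4 `CC(C)(O)CNc1nc(NCc2ccc(-c3ccco3)cc2)c2ncn(C3CCCC3)c2n1` keeps the furan-2-yl group but has 2-hydroxy-2-methylpropyl in place of 4-aminocyclohexyl on a nitrogen on an aromatic ring. Within the data shown here, all three measured compounds carry 4-aminocyclohexyl, so no measured step covers this change directly. The measured steps bear on it only as a guide to size, the largest being a 21-fold lower number from compound 1 to compound 3 (1.33 log units; beyond the scatter), where a single change separates compound 1 and compound 3.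

The direction is a judgement rather than a measured trend: compound 3 already stands lowest at 71 nM, so a rise seems more likely than a further fall. The expected step is a 4.9-fold higher number from compound 3 to compound 4 (0.69 log units; beyond the scatter), towards weaker inhibition, and it is of modest to large size. For compound 4 the estimated value is 350 nM, with an expected range of 90 nM to 1300 nM.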

Compound 4, half-maximal inhibitory concentration: 14800 nM
Compound 4: the middle estimate sits 42-fold (1.63 log units) below what was measured, and the stated range ends below it.
By their numbers in this assay, from the lowest: compound 3; then compound 2; then compound 1; then compound 4.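

The series now has a reading at the nitrogen on an aromatic ring as well as at the aromatic carbon: in this assay the change to 2-hydroxy-2-methylpropyl gives a 210-fold higher number from compound 3 to compound 4 (2.32 log units; beyond the scatter) and exceeds every step among the 4-aminocyclohexyl compounds. With the furan-2-yl group held constant, the group on this nitrogen therefore has a very large bearing on the number, and the furan-2-yl group does not secure a low value by itself. The swap replaces a six-membered ring of carbon bearing a nitrogen with an open chain bearing an oxygen, going from 7 heavy atoms to 5, and nothing available shows which of these differences accounts for the step.

Ring, amine and hydroxyl all change together in this single swap, so the compounds shown do not separate their contributions. A 4-aminobutyl group would test the amine without the ring, and a 4-hydroxycyclohexyl group would test the ring with a hydroxyl in place of the amine, each on the furan-2-yl compound.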